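Sulfonyl for Carbonyl on the Ring Nitrogen

The source may hold more compounds than are shown below. What is called first, only, known or untested is meant among the compounds shown, and "the series" means these compounds.

Measured compounds:
compound 1, `COC(=O)CC(=O)N1N=C(c2ccc(-n3ccnc3)cc2)CC1c1ccc(N(C)C)cc1`: -0.1%
compound 2, `CN(C)c1ccc(C2CC(c3ccc(-n4ccnc4)cc3)=NN2C(=O)c2ccc(F)cc2)cc1`: -3.5%

In a functional assay on NCI-H1975 cells (Homo sapiens) for inhibition, read by sulforhodamine B assay, tested at 10 uM (on this read-out higher numbers stand for more inhibition at the one concentration tested (going by the name of the read-out) and lower numbers for less inhibition), compound 2 gives -3.5%, and compound 1 gives -0.1%; the two sit within the scatter of each other, as a number 3.4 percentage points lower from compound 1 to compound 2 (within the scatter) shows. Compound 3, `CN(C)c1ccc(C2CC(c3ccc(-n4ccnc4)cc3)=NN2S(=O)(=O)c2ccc([N+](=O)[O-])cc2)cc1`, differs from compound 2 by (4-nitrophenyl)sulfonyl in place of (4-fluorophenyl)carbonyl on an amine nitrogen in a ring. Going by the values given here, the only measured step, a number 3.4 percentage points lower from compound 1 to compound 2 (within the scatter), exchanges the group on the carbonyl carbon while the carbonyl itself stays, so it bears only loosely on this exchange of the whole group. Compound 3 is therefore expected to show no step beyond the scatter, a number 6.5 percentage points higher from compound 2 to compound 3 (within the scatter). For compound 3 the estimate is 3%, with a range from -10% to 22%.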

Compound 3, a percentage reported as inhibition, at one concentration (the size of the read-out at that concentration, not a potency): 53%
The estimate for compound 3 lay 50 percentage points below the measured number; measured number above the stated range.
By their numbers in this assay, from the lowest: compounds 2 and 1 (each within the scatter of the next); then compound 3.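

Going by these compounds alone, at this ring nitrogen, (4-nitrophenyl)sulfonyl is the first exchange to move the number in this assay beyond the scatter (a number 56.5 percentage points higher from compound 2 to compound 3 (beyond the scatter); a number 53.1 percentage points higher from compound 1 to compound 3 (beyond the scatter)). The two carbonyl groups on the shared core stay within the scatter of each other, so this position does respond to a change of the whole group. Nothing measured here bears on why the step is so large. The sulfonyl and the nitro group enter together, so the compounds shown leave open which of them goes with the step. A (4-fluorophenyl)sulfonyl or a (4-nitrophenyl)carbonyl group would separate the two.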